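Adding an amino group to the weaker compound

The source may report more compounds than this note shows. Statements on the series, on what has been measured and on what is new or still open speak of the compounds shown alone.

A pair of compounds sharing one core has been measured in a functional assay on A2780 cells (Homo sapiens) for antiproliferative activity, with a stated time of 72 h; a higher number here means a weaker inhibitor, a lower number a stronger inhibitor. Compound 1 (`O=C1NCCc2[nH]c(-c3ccncc3F)cc21`) gives 200 nM, while compound 2 (`O=C1NCCc2[nH]c(-c3ccncn3)cc21`) gives 5500 nM. Compound 2 therefore has the higher of the two numbers, which makes it the weaker inhibitor, and the gap lies beyond the scatter. Compound 3 (`Nc1nccc(-c2cc3c([nH]2)CCNC3=O)n1`) is compound 2 with a single change: amino in place of hydrogen on an aromatic carbon, between two ring nitrogen atoms (amino in place of hydrogen on an aromatic carbon). Among the compounds with values here, no measured pair shows what this change does, so any forecast is a judgement. Compound 1, at 200 nM, shows that numbers far lower than that of compound 2 are reachable on this core. A clear move toward stronger inhibition, beyond the scatter, is expected, with an estimated step of a 6.1-fold lower number from compound 2 to compound 3 (0.79 log units; beyond the scatter). The estimate for compound 3 is 900 nM, with an expected range from 250 nM to 3000 nM.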

Compound 3, half-maximal inhibitory concentration: 1700 nM
The estimate for compound 3 lay 1.9-fold (0.28 log units) below the measured number, and the stated range covers the measured number.
By their numbers in this assay, from the lowest: compound 1; then compound 3; then compound 2.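

In this assay, amino in place of hydrogen on an aromatic carbon, between two ring nitrogen atoms, gives a 3.2-fold lower number from compound 2 to compound 3 (0.51 log units; beyond the scatter), a modest step but one beyond the scatter. Within the data shown here, this is the first measured change at this position, and it shows that the position accepts a group larger than hydrogen and that the number falls when amino enters. No measurement shown here explains why the number falls.

From the compounds shown here alone, it remains open whether this gain is specific to amino or would also appear with a methyl group, a hydroxyl group or a methylamino group at the same position. Going by these compounds, it is also open whether adding an amino group to the aromatic ring of compound 1 would lower its number too.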